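Cyclised amine side chain on the shared core

The source may hold more compounds than are shown below. What is called first, only, known or untested is meant among the compounds shown, and "the series" means these compounds.

Two compounds of this series have numbers in an assay for binding affinity to Alpha-1B adrenergic receptor (Homo sapiens); a higher number here means a weaker inhibitor, a lower number a stronger inhibitor. Compound 1 `CN(C)CCn1nc(Cc2ccc(Cl)cc2)c2ccccc2c1=O` gives 200 nM, the higher of the two. Compound 2 `O=c1c2ccccc2c(Cc2ccc(Cl)cc2)nn1C[C@H]1CCCN1CCCCCc1ccc(OCCCN2CCCCCC2)cc1`, which carries a far longer substituted chain on the core nitrogen, gives 50.1 nM, and the gap between them lies beyond the usual scatter. Going by the values given here, no pair that differs in a single place has been measured, so no step size is known from the data themselves. Compound 3 `CN1CCC(Cn2nc(Cc3ccc(Cl)cc3)c3ccccc3c2=O)C1` is the next candidate: 1-methylpyrrolidin-3-yl in place of (dimethylamino)methyl on a saturated chain carbon bound to an aromatic nitrogen. The amine nitrogen is kept and folded into a ring, with the chain lengthened by one carbon. With nothing of this kind measured, the step is expected to be small, a 1.3-fold lower number from compound 1 to compound 3 (0.12 log units; within the scatter), within the scatter or at most a modest move toward a lower number. For compound 3 the estimate in this assay is 150 nM, with a range from 50 nM to 450 nM.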

Compound 3, inhibition constant: 79.4 nM
Estimate against measurement, compound 3: 1.9-fold (0.28 log units) above; measured number inside the range.
By their numbers in this assay, from the lowest: compounds 2 and 3 (each within the scatter of the next); then compound 1.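

In this assay, going by these compounds alone, the change to 1-methylpyrrolidin-3-yl from (dimethylamino)methyl, on a saturated chain carbon bound to an aromatic nitrogen, gives a 2.5-fold lower number from compound 1 to compound 3 (0.40 log units; beyond the scatter) and so provides the first step read at a single place. The step is modest, but it shows that this position does not merely tolerate the amine nitrogen being folded into a five-membered non-aromatic ring: the number moves beyond the scatter toward a stronger inhibitor. Nothing available bears on the origin of this step.

The step combines ring formation with a lengthened chain, so the share of each stays unresolved, and a dimethylamino group on a longer open chain would separate them. As far as these compounds go, whether a six-membered ring such as 1-methylpiperidin-4-yl, or the pyrrolidine with a hydrogen in place of the methyl on nitrogen, behaves alike also remains open.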